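This account rests on a few compounds, and the source may have more. Where it says the series, first, only, none or still open, it means among the compounds named here.

Among the compounds with values here, compound 1 `COc1cc(-c2nn(-c3cccc(NC(=O)Nc4cc(C(F)(F)F)cc(C(F)(F)F)c4)c3)cc2-c2ccncc2)ccc1Cl` is one of two compounds measured in a functional assay on NCI-H23 cells (Homo sapiens) for inhibition, read by sulforhodamine B assay, with a stated time of 48 h; a higher number here means a weaker inhibitor of growth, a lower number a stronger inhibitor of growth. In this assay compound 1 gives 1090 nM. The second compound, compound 2 `O=C(Nc1cccc(-n2cc(-c3ccncc3)c(-c3ccc(Cl)c(O)c3)n2)c1)Nc1ccc(Cl)c(Cl)c1`, gives 1220 nM in this assay. Compound 1 has the lower of the two numbers, but the gap between compound 1 and compound 2 falls within the usual scatter of repeated measurements, so the two cannot be told apart on these figures.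

Compound 3 `COc1cc(-c2nn(-c3cccc(NC(=O)Nc4cccc(C(F)(F)F)c4)c3)cc2-c2ccncc2)ccc1Cl` has not yet been measured in this assay. It differs from compound 1 in one place: hydrogen in place of trifluoromethyl on an aromatic carbon. Within the data shown here, no measured pair shows what such a change does here, so the expectation rests on compound 1 alone. A modest loss of growth inhibition is expected, with a step of a 1.7-fold higher number from compound 1 to compound 3 (0.22 log units; within the scatter) from compound 1 to compound 3. Compound 3 is therefore estimated at 1800 nM in this assay, within a range from 700 nM to 5000 nM.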

Compound 3, concentration for 50% growth inhibition: 1180 nM
The estimate for compound 3 lay 1.5-fold (0.18 log units) above the measured number, within the range that was stated.
By their numbers in this assay, from the lowest: compounds 1, 3 and 2 (each within the scatter of the next).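

Replacing one of the two trifluoromethyl groups with hydrogen on this aromatic carbon gives, in this assay, a 1.1-fold higher number from compound 1 to compound 3 (0.03 log units; within the scatter) and so leaves compound 1 and compound 3 indistinguishable. Within the data shown here, this is the first direct reading of this position, as the earlier pair differed in more than one place and could not isolate any single change. On these figures, growth inhibition in these cells does not depend measurably on having this trifluoromethyl group rather than hydrogen, and no measurement here explains that result.

From the compounds shown here alone, it remains open whether the other trifluoromethyl group could also be replaced by hydrogen without a measurable step. It is also unknown how larger or different groups would behave at the position now carrying hydrogen, such as an amine or a carboxylic acid.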